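A Benzoyl Arm in Place of Naphthalene

A few compounds are considered here, and "the series" means these few. Any claim that something is new, unique, unknown or untested is made for them only; others in the source may bear on it.

Three measured compounds share one core and differ only in the group that sits on a saturated chain carbon bound to a sulfur. Compound 1 `Cc1cc(Nc2cc(-c3ccccc3)[nH]n2)n2nc(SCc3nc4ccccc4[nH]3)nc2n1` carries 1H-benzimidazol-2-yl there and gives 2730 nM in a functional assay on MCF7 cells (Homo sapiens) for inhibition, read by MTT assay, with a stated time of 72 h; a lower number here means a stronger inhibitor, a higher number a weaker inhibitor. Compound 2 `Cc1cc(Nc2cc(-c3ccccc3)[nH]n2)n2nc(SCc3ccc(F)cc3)nc2n1` carries 4-fluorophenyl and gives 4020 nM in this assay. Compound 3 `Cc1cc(Nc2cc(-c3ccccc3)[nH]n2)n2nc(SCc3cccc4ccccc34)nc2n1` carries naphthalen-1-yl and gives 7560 nM in this assay. Compound 3 thus holds the highest of the three numbers: the step of a 2.8-fold higher number from compound 1 to compound 3 (0.44 log units; beyond the scatter) lies beyond the scatter, while a 1.9-fold higher number from compound 2 to compound 3 (0.27 log units; within the scatter) and a 1.5-fold higher number from compound 1 to compound 2 (0.17 log units; within the scatter) both stay within it.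

Compound 4 `Cc1cc(Nc2cc(-c3ccccc3)[nH]n2)n2nc(SCC(=O)c3ccccc3)nc2n1` has not been measured. It differs from compound 3 in one place: benzoyl in place of naphthalen-1-yl on a saturated chain carbon bound to a sulfur. Among the compounds with values here, no measured step places a benzoyl, or any group carrying a carbonyl, on that chain carbon, so the steps that bear on it are indirect. The steps of a 2.8-fold higher number from compound 1 to compound 3 (0.44 log units; beyond the scatter) and a 1.9-fold higher number from compound 2 to compound 3 (0.27 log units; within the scatter) show that the group in this position moves the number only by modest amounts, and that compound 1 gave a lower number than compound 3. A modest lower number is therefore expected, a 1.7-fold lower number from compound 3 to compound 4 (0.23 log units; within the scatter). Compound 4 is estimated to give 4500 nM in this assay, with a range from 2000 nM to 12000 nM.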

Compound 4, half-maximal inhibitory concentration: 5240 nM
Estimate against measurement, compound 4: 1.2-fold (0.07 log units) below; the range from low to high includes it.
By their numbers in this assay, from the lowest: compounds 1, 2, 4 and 3 (each within the scatter of the next, the first and the last beyond it).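

Within the data shown here, with benzoyl, this position now holds a group with a carbonyl and only one six-membered aromatic ring of carbon, and in this assay all three new steps stay within the scatter: a 1.4-fold lower number from compound 3 to compound 4 (0.16 log units; within the scatter) and a 1.3-fold higher number from compound 2 to compound 4 (0.12 log units; within the scatter) and a 1.9-fold higher number from compound 1 to compound 4 (0.28 log units; within the scatter). Compound 4 therefore cannot be told apart from any of the other three compounds, even though the step of a 2.8-fold higher number from compound 1 to compound 3 (0.44 log units; beyond the scatter) lies beyond the scatter, so the change from naphthalen-1-yl to benzoyl gives no readable shift on a saturated chain carbon bound to a sulfur. Nothing shown accounts for these numbers or says what the carbonyl contributes.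

The four compounds leave open whether a carboxylic acid, an amine or an amide on that chain carbon, or a longer chain in its place, would give a number clearly apart from these. They also leave open whether a substituted benzoyl, such as 4-fluorobenzoyl, would give a number beyond the scatter of compound 4 in this assay, and whether any such step would hold on another core.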